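A few compounds are considered here, and "the series" means these few. Any claim that something is new, unique, unknown or untested is made for them only; others in the source may bear on it.

For the measured compounds named here, compound 2 `COc1ccc2nccc(C3CN(C4CCN(Cc5ccc6ccccc6c5)CC4)C(=O)O3)c2c1` gives 1260 nM in an in vitro functional assay on RBL cells for antagonist activity at C-C chemokine receptor type 8 (Homo sapiens), read by FLIPR and calcium flux (on this read-out lower numbers stand for stronger inhibition and higher numbers for weaker inhibition), and stands lowest of the two numbers so far, while compound 1 `COc1ccc2nccc(C3CN(C4CCN(Cc5cc6ccccc6n5C)CC4)C(=O)O3)c2c1` gives 3160 nM. Compound 3 `COc1ccc2nccc(C3CN(C4CCN(Cc5ccccc5)CC4)C(=O)O3)c2c1` differs from compound 2 by phenyl in place of naphthalen-2-yl on a saturated chain carbon bound to an amine nitrogen in a ring. Going by the values given here, the only measured step at this place, a 2.5-fold lower number from compound 1 to compound 2 (0.40 log units; beyond the scatter), exchanged one two-ring aromatic group for another and so says nothing directly about shrinking to a single ring. Among the compounds with values here, with that step as the sole guide, a weakening beyond the scatter is expected for compound 3, roughly a 2.5-fold higher number from compound 2 to compound 3 (0.40 log units; beyond the scatter). Compound 3 is therefore estimated at 3200 nM, within 1000 nM to 10000 nM.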

Compound 3, half-maximal inhibitory concentration: 12600 nM
Beside the measured number, compound 3's estimate is 3.9-fold (0.60 log units) below it, outside the stated range (above it).
By their numbers in this assay, from the lowest: compound 2; then compound 1; then compound 3.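

At this carbon, the second aromatic ring matters: phenyl gives a 10-fold higher number from compound 2 to compound 3 (1.00 log units; beyond the scatter) and also a 4.0-fold higher number from compound 1 to compound 3 (0.60 log units; beyond the scatter) in this assay, so both two-ring groups in these compounds, naphthalen-2-yl and 1-methyl-1H-indol-2-yl, stand ahead of the single ring. Among these three compounds, none goes against that order. No measurement here gives a reason for the loss.

Still open, from the compounds shown here alone, is whether a chlorine atom or a methoxy group on the phenyl ring would recover the lost inhibition. Also open, going by these compounds, is how a saturated cyclohexyl group would compare at this place.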